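Thiazolyl-pyrazole acids: swapping the aryl group on BJAB cells

The compounds below may be only part of what the source reports. "The series", "measured", "known", "first", "only" and "open" are said of these compounds alone.

Measured compounds:
compound 1 `COc1ccccc1-c1c(C)nn(-c2nc(-c3ccc(Cl)c(Cl)c3)c(SC(C)C)s2)c1C(=O)O`: 14700 nM
compound 2 `Cc1ccc(-c2c(C)nn(-c3nc(-c4ccc(Cl)c(Cl)c4)c(SC(C)C)s3)c2C(=O)O)cc1`: 3800 nM
compound 3 `Cc1cc(C#N)cc(-c2c(C)nn(-c3nc(-c4ccc(Cl)c(Cl)c4)c(SC(C)C)s3)c2C(=O)O)c1`: 4800 nM

Compound 3 `Cc1cc(C#N)cc(-c2c(C)nn(-c3nc(-c4ccc(Cl)c(Cl)c4)c(SC(C)C)s3)c2C(=O)O)c1` stands second highest of the three numbers in a functional assay on BJAB cells (Homo sapiens) for antiproliferative activity, with a stated time of 4 days; a higher number here means that more compound is needed for the effect, a lower number that less compound is needed. Its nearest neighbour is compound 2, with a 1.3-fold higher number from compound 2 to compound 3 (0.10 log units; within the scatter), a gap within the scatter, so the two cannot be ordered. Its furthest neighbour is compound 1, with a 3.1-fold lower number from compound 1 to compound 3 (0.49 log units; beyond the scatter).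

Compound 4 `Cc1nn(-c2nc(-c3ccc(Cl)c(Cl)c3)c(SC(C)C)s2)c(C(=O)O)c1-c1ccccc1Cl` differs from compound 3 in one place: 2-chlorophenyl in place of 3-cyano-5-methylphenyl on an aromatic carbon. The 2-chlorophenyl of compound 4 resembles the 2-methoxyphenyl of compound 1 in its pattern more than it resembles the groups of compound 2 or compound 3. The step that bears on it is therefore a 3.1-fold lower number from compound 1 to compound 3 (0.49 log units; beyond the scatter), a modest change, read in reverse. A similar or somewhat smaller move in the opposite direction is expected, giving a higher number for compound 4 in this assay, estimated as a 1.9-fold higher number from compound 3 to compound 4 (0.27 log units; within the scatter). Compound 4 is thus expected to show about 9000 nM, most likely between 3500 nM and 25000 nM.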

Compound 4, half-maximal effective concentration: 13100 nM
Compound 4: the middle estimate sits 1.5-fold (0.16 log units) below what was measured; the measured number falls inside the stated range.
By their numbers in this assay, from the lowest: compounds 2 and 3 (each within the scatter of the next); then compounds 4 and 1 (each within the scatter of the next).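

In this assay, 2-chlorophenyl on this aromatic carbon gives a 2.7-fold higher number from compound 3 to compound 4 (0.44 log units; beyond the scatter) in place of 3-cyano-5-methylphenyl and a 3.4-fold higher number from compound 2 to compound 4 (0.54 log units; beyond the scatter) in place of 4-methylphenyl. Chloro in place of methoxy gives a 1.1-fold lower number from compound 1 to compound 4 (0.05 log units; within the scatter), so the 2-chlorophenyl and 2-methoxyphenyl groups cannot be told apart here. Compound 4 thus shows that the higher number of compound 1 is not confined to methoxy, and among these four compounds both 2-substituted phenyl groups stand above the other two, with none going against this. Nothing measured here accounts for the difference.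

The compounds shown leave open whether a 4-chlorophenyl group would track the 4-methylphenyl of compound 2 or the 2-chlorophenyl of compound 4. On these data alone, how an unsubstituted phenyl or a 2-aminophenyl group would read at this position also remains open.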